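This account rests on a few compounds, and the source may have more. Where it says the series, first, only, none or still open, it means among the compounds named here.

Compound 1 `CO[C@H](C(=O)NS(=O)(=O)OC[C@H]1O[C@@H](n2cnc3c(N)nc(Cl)nc32)[C@H](O)[C@@H]1O)[C@H](OC)C(C)C` was examined in an ADME assay on MRC5 cells (Homo sapiens) for antiproliferative activity, read by sulforhodamine B assay, with a stated time of 72 h; on this read-out lower numbers stand for stronger inhibition and higher numbers for weaker inhibition. In this assay compound 1 gives only a limit, > 20000 nM. Compound 2 `CC(C)C[C@H](O)C(=O)NS(=O)(=O)OC[C@H]1O[C@@H](n2cnc3c(=O)[nH]cnc32)[C@H](O)[C@@H]1O` likewise reaches only a limit, > 20000 nM, in this assay. Compound 3 `Nc1nc(I)nc2c1ncn2[C@@H]1O[C@H](COS(=O)(=O)NC(=O)[C@@H](O)[C@H](O)C2CC2)[C@@H](O)[C@H]1O` also gives only a limit, > 20000 nM, in this assay. Compound 1 therefore stands nowhere apart from the others: every value shown sits at the limit of > 20000 nM in this assay, at which 3 of the 3 values shown sit. Compound 4 `CC(C)C[C@H](Cl)C(=O)NS(=O)(=O)OC[C@H]1O[C@@H](n2cnc3c(N)nc(Cl)nc32)[C@H](O)[C@@H]1O` differs from compound 1 in one place: a group of 6 heavy atoms (5 carbon, 1 chlorine; no ring) in place of a group of 9 heavy atoms (7 carbon, 2 oxygen; no ring), on a carbonyl carbon. Going by the values given here, with no step between measured compounds to lean on, and every number so far a limit, the step that the limit leaves unreadable from compound 1 to compound 4 is estimated to be flat, with no shift beyond the scatter expected. Compound 4 is accordingly expected to give about 25000 nM, within a range from 8000 nM to 80000 nM, and most likely to be reported again only as a limit.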

Compound 4, half-maximal inhibitory concentration: > 20000 nM
Compound 4: a limit, no number; the forecaster's own chance of this, stated with the estimate: 75%; the middle value is on the limit's open side.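

In this assay, going by these compounds alone, compound 4 again gives only a limit of > 20000 nM and so no step from compound 1 to compound 4 can be read. The compounds shown leave open how any of them compare in this assay because all of them share one limit: the limit of > 20000 nM in this assay, at which 4 of the 4 values shown sit.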